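The source may report more compounds than this note shows. Statements on the series, on what has been measured and on what is new or still open speak of the compounds shown alone.

Measured in a functional assay on MDA-MB-231 cells (Homo sapiens) for antiproliferative activity, read by CCK-8 assay, with a stated time of 72 h; a higher number here means a weaker inhibitor, a lower number a stronger inhibitor:
compound 1 `COc1ccc(C(=O)Nc2ccc(C(=O)/C=C/c3nc(C)c(C)nc3C)cc2)cc1OC` gives 3360 nM;
compound 2 `COc1cccc(OC)c1C(=O)Nc1ccc(C(=O)/C=C/c2nc(C)c(C)nc2C)cc1` gives 3850 nM;
compound 3 `COc1ccc(C(=O)Nc2ccc(C(=O)/C=C/c3nc(C)c(C)nc3C)cc2)cc1` gives 1600 nM.

All three share the same core and differ only in the ring attached to the amide carbonyl. Compound 3 has the lowest number of the three, so it is the strongest inhibitor in this assay: its nearest neighbour is compound 1, and compound 2 lies a little further away.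

Compound 4 `COc1cc(OC)cc(C(=O)Nc2ccc(C(=O)/C=C/c3nc(C)c(C)nc3C)cc2)c1` has not yet been measured. Compared with compound 3 the change is 3,5-dimethoxyphenyl in place of 4-methoxyphenyl on a carbonyl carbon.

Among the compounds with values here, two measured steps bear on this. Going from compound 1 to compound 3 removes one methoxy group and gives a 2.1-fold lower number from compound 1 to compound 3 (0.32 log units; beyond the scatter); going from compound 2 to compound 3 swaps a dimethoxyphenyl for the single-methoxy ring and gives a 2.4-fold lower number from compound 2 to compound 3 (0.38 log units; beyond the scatter). In both cases the ring carrying two methoxy groups gave the higher number, and compound 4 again carries two, though in an arrangement not yet tested. A modest rise in this assay is therefore expected for compound 4, with the step of a 1.9-fold higher number from compound 3 to compound 4 (0.27 log units; within the scatter) estimated. Compound 4 is expected to give about 3000 nM, within a range from 1500 nM to 6500 nM.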

Compound 4, half-maximal inhibitory concentration: 11600 nM
Compound 4: the middle estimate sits 3.9-fold (0.59 log units) below what was measured; measured number outside the range, above it.
By their numbers in this assay, from the lowest: compound 3; then compounds 1 and 2 (each within the scatter of the next); then compound 4.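

In this assay, the count of methoxy groups on the ring attached to the amide carbonyl no longer tells the whole story, since the 3,5-dimethoxyphenyl ring gives a 3.5-fold higher number from compound 1 to compound 4 (0.54 log units; beyond the scatter) and also a 3.0-fold higher number from compound 2 to compound 4 (0.48 log units; beyond the scatter) even though all three of these compounds carry two methoxy groups. Their arrangement on the ring therefore matters here, and the step from the single-methoxy ring, a 7.3-fold higher number from compound 3 to compound 4 (0.86 log units; beyond the scatter) in the same assay, leaves compound 4 as the weakest of the four, while compound 3 remains the strongest. No measurement shown here offers an explanation for why this arrangement costs so much activity.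

The compounds shown leave open whether any methoxy group is needed at all, as a plain phenyl ring would show by comparison with the 4-methoxyphenyl ring of compound 3. They also leave open whether a different group in place of the methoxy, such as a hydroxyl, a fluorine atom or a dimethylamino group, would lower the number further or raise it.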